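The compounds below may be only part of what the source reports. "The series", "measured", "known", "first", "only" and "open" are said of these compounds alone.

Working notes on the series.

Three compounds of the shared core have been run in an ADME assay on L6 cells (Rattus norvegicus) for cytotoxicity, read by resazurin assay, with a stated time of 72 h; a higher number here means a weaker inhibitor, a lower number a stronger inhibitor. Compound 1 `N/C(CC(O)c1ccc2ccccc2c1)=N\N=C\c1ccc(Cl)c(Cl)c1` gives 100000 nM in this assay, compound 2 `C/C(=N\N=C(/N)CC(O)c1cccc2ccccc12)c1ccc(F)cc1` gives 34000 nM, and compound 3 `N/C(CC(O)c1cccc2ccccc12)=N\N=C\c1cccnc1` gives 22000 nM. Compound 3 thus carries the smallest of the three numbers, but the picture is uneven: its gap to compound 1 lies beyond the scatter, whereas its gap to compound 2 lies within it, so compound 3 and compound 2 cannot be told apart on these data. Within the data shown here, no two measured compounds differ in a single place, so no single structural step has yet been read in this assay, and all three pairs differ in more than one place at once.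

Compound 4 `N/C(CC(O)c1cccc2ccccc12)=N\N=C\c1ccco1` is the next candidate and differs from compound 3 in one place: furan-2-yl in place of pyridin-3-yl on a carbon with a double bond to nitrogen. Nothing measured bears directly on this exchange. For this assay the expected step is a 1.1-fold higher number from compound 3 to compound 4 (0.06 log units; within the scatter), that is, none beyond the scatter and in no set direction, since compound 3 at 22000 nM is the only anchor. Compound 4 is therefore estimated at 25000 nM, with a range from 8000 nM to 80000 nM.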

Compound 4, half-maximal inhibitory concentration: 145000 nM
Beside the measured number, compound 4's estimate is 5.8-fold (0.76 log units) below it, outside the stated range (above it).
By their numbers in this assay, from the lowest: compounds 3 and 2 (each within the scatter of the next); then compounds 1 and 4 (each within the scatter of the next).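

In this assay, among these compounds, the change of furan-2-yl in place of pyridin-3-yl on a carbon with a double bond to nitrogen gives a 6.6-fold higher number from compound 3 to compound 4 (0.82 log units; beyond the scatter) and is the first single-place reading, showing that the group at this position can by itself move the number beyond the scatter. The exchange replaces a six-membered aromatic ring carrying a nitrogen with a five-membered aromatic ring carrying an oxygen, while both groups have the same counts of hydrogen-bond donors and acceptors, so these counts do not separate the two groups even though the numbers differ. No measurement available here accounts for the step.

From the compounds shown here alone, with one step at this position, it remains open whether the shift follows the ring size or the identity of the hetero atom, a question that thiophen-2-yl or pyridin-2-yl at the same place could help to separate. Going by these compounds, it also remains open whether the same exchange would give a step of similar size in the settings of compound 1 or compound 2, which differ from compound 3 in more than one place.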